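From propyl to 2-nitrophenyl on the sulfonyl sulfur

The source may hold more compounds than are shown below. What is called first, only, known or untested is meant among the compounds shown, and "the series" means these compounds.

Values in an ADME assay on HEK293 cells (Homo sapiens) for antiproliferative activity, read by MTT assay, with a stated time of 48 h; on this read-out higher numbers stand for weaker inhibition and lower numbers for stronger inhibition:
Compound 1 `COc1ccc(S(=O)(=O)n2cc(/C=C/C(=O)c3ccncc3)c3ccccc32)cc1`: > 150000 nM (a limit)
Compound 2 `CCCS(=O)(=O)n1cc(/C=C/C(=O)c2ccncc2)c2ccccc21`: > 150000 nM (a limit)

Compound 2 has no exact number here, only the limit > 150000 nM. Compound 1 also has only a limit, and (the limit of > 150000 nM in this assay, at which 2 of the 2 values shown sit). Compound 3 `O=C(/C=C/c1cn(S(=O)(=O)c2ccccc2[N+](=O)[O-])c2ccccc12)c1ccncc1` carries 2-nitrophenyl in place of propyl on a sulfonyl sulfur. Among the measured compounds shown here, one measured step bears on this change, since it falls at the same sulfur: a step that the two limits leave unreadable from compound 1 to compound 2. Its size cannot be known, so it offers no measured size to carry over. Compound 1 keeps an aromatic ring at this place, and its limit is > 150000 nM. No step beyond the scatter is therefore expected in this assay, and another limit is the likeliest report. The expected step is a number no higher from compound 2 to compound 3 (the limit leaves the size open). Compound 3 is estimated at 150000 nM, with an expected range of 70000 nM to 300000 nM.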

Compound 3, half-maximal inhibitory concentration: > 150000 nM
Compound 3 was reported as a limit (the forecaster's own chance of this, stated with the estimate: 75%); the middle value sits exactly at the limit.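

Compound 3, like compound 1 and compound 2, is reported only as a limit in this assay, so the steps among these three compounds cannot be read: the limit of > 150000 nM in this assay, at which 3 of the 3 values shown sit.

The compounds shown leave open whether propyl, 4-methoxyphenyl or 2-nitrophenyl on the sulfonyl sulfur makes any difference in this assay.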